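The compounds below may be only part of what the source reports. "The series", "measured", "known", "first", "only" and "open" are said of these compounds alone.

Measured so far in an ADME assay on the whole organism (strain Sprague-Dawley) for metabolic stability, with Rattus norvegicus as the target; a lower number here means that the compound disappears faster, a higher number that the compound lasts longer:
- compound 1 `Nc1nc2c(s1)CCC[C@H]2C(=O)Nc1ccc(C[C@@H]2CC[C@H]([C@H](O)c3ccccc3)N2)cc1`: 3 h
- compound 2 `Nc1nc2c(s1)CC[C@H]2C(=O)Nc1ccc(C[C@@H]2CC[C@H]([C@H](O)c3cccnc3)N2)cc1`: 4 h

The half-life of compound 1, 3 h, and that of compound 2, 4 h, lie within the usual scatter of repeated measurements, so the two compounds cannot be told apart on these numbers.

The next compound to be tested is compound 3 `O=C(Nc1ccc(C[C@@H]2CC[C@H]([C@H](O)c3ccccc3)N2)cc1)[C@@H]1CCc2scnc21`. It differs from compound 1 in one place, on a carbonyl carbon whose other neighbour is an amide-type nitrogen: a group of 8 heavy atoms (6 carbon, 1 nitrogen, 1 sulfur; one five-membered non-aromatic ring of carbon only, one five-membered aromatic ring with 2 hetero atoms) in place of a group of 10 heavy atoms (7 carbon, 2 nitrogen, 1 sulfur; one five-membered aromatic ring with 2 hetero atoms, one six-membered non-aromatic ring of carbon only), on a carbonyl carbon. Both groups hold one five-membered aromatic ring with 2 hetero atoms, while the six-membered non-aromatic ring of carbon only gives way to a five-membered non-aromatic ring of carbon only.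

For the measured compounds named here, no pair of measured compounds differs in just one place, so the data give no direct measure of such a change. With only compound 1 at 3 h as the starting point, no step beyond the scatter is expected in this assay, and no direction is favoured. The expected change is a 1.2-fold lower number from compound 1 to compound 3 (0.08 log units; within the scatter). For compound 3 the estimated half-life is 2.5 h, with an expected range of 1 h to 5 h.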

Compound 3, half-life: 1 h
Compound 3: middle estimate off by 2.5-fold (0.40 log units), on the high side; measured number inside the range.
By their numbers in this assay, from the lowest: compound 3; then compounds 1 and 2 (each within the scatter of the next).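

In this assay, the group on the carbonyl carbon whose other neighbour is the amide-type nitrogen proves able to change the result: replacing the group holding a six-membered non-aromatic ring of carbon only with the one holding a five-membered non-aromatic ring of carbon only comes with a 3.0-fold lower number from compound 1 to compound 3 (0.48 log units; beyond the scatter). For the compounds shown here, this is the first direct comparison of two compounds that differ in just one place, and it shows that a change at this position alone can go with faster disappearance of the compound, which the earlier pair could not show. Nothing measured here explains why the number falls.

The swap changes more than ring size, since the group that leaves has 1 hydrogen-bond donor and 3 hydrogen-bond acceptors and the group that enters has 0 hydrogen-bond donors and 2 hydrogen-bond acceptors, so this single step cannot separate these differences. The compounds shown also leave open how a different kind of group on this carbonyl carbon, such as a plain cyclohexyl ring or a morpholine, would behave.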